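Adding hydroxy to the core of compound 2

This account rests on a few compounds, and the source may have more. Where it says the series, first, only, none or still open, it means among the compounds named here.

compound 1 `COc1ccc2c(c1O)CCCC=C2c1cc(OC)c(OC)c(OC)c1`: < 0.03 nM
compound 2 `COc1ccc2c(c1)CCCC(c1cc(OC)c(OC)c(OC)c1)=C2`: 440 nM
compound 3 `COc1ccc(CC2CCCCc3c2cc(OC)c(OC)c3OC)c(O)c1O`: "not determined" (no result reported)

For the measured compounds named here, in a functional assay on SK-OV-3 cells (Homo sapiens) for inhibition, read by sulforhodamine B assay, with a stated time of 48 h (a lower number here means a stronger inhibitor of growth, a higher number a weaker inhibitor of growth), compound 2 gives 440 nM, the only actual number so far. The entry for compound 1 is a limit. Compound 3 has no result.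

Compound 4 `COc1ccc2c(c1O)CCCC(c1cc(OC)c(OC)c(OC)c1)=C2` is still to be measured and differs from compound 2 as follows: hydroxy in place of hydrogen on an aromatic carbon. Going by the values given here, no measured pair isolates this change. The expectation rests on compound 1, which also carries a hydroxy group and whose < 0.03 nM is a limit. The expected change is an 11-fold lower number from compound 2 to compound 4 (1.04 log units; beyond the scatter), towards stronger inhibition and beyond the scatter. Compound 4 is estimated at 40 nM, with an expected range of 2 nM to 600 nM.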

Compound 4, concentration for 50% growth inhibition: 270 nM
For compound 4 the middle estimate is 6.8-fold (0.83 log units) below the measured one, and the stated range covers the measured number.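

In this assay, hydroxy in place of hydrogen on an aromatic carbon, ortho to a methoxy group, gives a 1.6-fold lower number from compound 2 to compound 4 (0.21 log units; within the scatter), so the hydroxy group has no effect here that can be separated from the scatter. For the compounds shown here, this is the first measured pair to isolate this change. Compound 1 also carries hydroxy, but its entry is a limit, not a number: the limit of < 0.03 nM in this assay, at which 1 of the 4 values shown sits.

As far as these compounds go, what the same hydroxy group does on the core of compound 1 stays open. So does whether an amine or an ethoxy group on this carbon would give a step beyond the scatter.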